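This account rests on a few compounds, and the source may have more. Where it says the series, first, only, none or still open, it means among the compounds named here.

Measured in an ADME assay on cells (Erythrocyte, Homo sapiens) for activation, read by hemolysis, with a stated time of 30 min, tested at 5 mM; on this read-out higher numbers stand for a stronger effect at the one concentration tested and lower numbers for a weaker effect:

compound 1, `COc1ccc(-c2ccc(-c3ccc(C(=N)N)o3)o2)cc1`, gives 36.3%
compound 2, `COc1cccc(-c2ccc(-c3ccc(C(=N)N)s3)s2)c1`, gives 39%
compound 3, `N=C(N)c1ccc(-c2ccc(-c3cncc4ccccc34)s2)s1`, gives 4%

Among these three numbers compound 1 holds the second highest. Compound 2 lies nearest to it, a small distance above that stays within the usual scatter of this kind of measurement, so the two cannot be ordered. Compound 3 lies far below, a gap well beyond the scatter.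

The compound not yet measured is compound 4, `N=C(N)c1ccc(-c2ccc(-c3ccc(F)cc3)o2)o1`. It keeps the core of compound 1 and differs in one place: fluoro in place of methoxy on an aromatic carbon.

Going by the values given here, no pair of measured compounds differs in a single place, so no measured step guides this change. The nearest hint comes from compound 1 and compound 2, whose values agree within the scatter although their cores and the position of the methoxy group both differ. On that basis the step from compound 1 to compound 4 in this assay is expected to stay within the scatter, with no clear direction; the expected step is a number 3.3 percentage points lower from compound 1 to compound 4 (within the scatter). Compound 4 is therefore estimated at 33%, most likely between 15% and 55%.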

Compound 4, a percentage reported as activity, at one concentration (the size of the read-out at that concentration, not a potency): 66.3%
Beside the measured number, compound 4's estimate is 33.3 percentage points below it, and the stated range ends below it.
By their numbers in this assay, from the lowest: compound 3; then compounds 1 and 2 (each within the scatter of the next); then compound 4.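

Going by these compounds alone, the step of a number 30 percentage points higher from compound 1 to compound 4 (beyond the scatter) shows that in this assay this place, on an aromatic carbon of a six-membered aromatic ring of carbon only and para to a large group, is not neutral on the shared core, something the earlier compounds, with no pair differing in one place, could not show. In this single pair, fluoro, with one heavy atom and no hydrogen-bond acceptor, goes with the stronger effect at the one concentration tested, although one pair sets no trend. Nothing available here accounts for the size or direction of this step.

As far as these compounds go, it remains open whether the same change would act alike on the core of compound 2. What chloro, hydroxyl or an amine would give at this place is also unknown.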